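Chlorinated Pyridine in Place of Phenyl: Expected Effect

The source may report more compounds than this note shows. Statements on the series, on what has been measured and on what is new or still open speak of the compounds shown alone.

Compound 1 `c1ccc(NCc2ccc(CNc3ccccc3)cc2)cc1`, compound 2 `c1ccc(NCc2ccc(CNc3ncccn3)cc2)cc1` and compound 3 `Fc1ccc(NCc2ccc(CNc3ncccn3)cc2)nc1` share one core. In a functional assay on MDA-MB-231 cells for antagonist activity at C-X-C chemokine receptor type 4 (Homo sapiens), tested at 10 nM (on this read-out higher numbers stand for a stronger effect at the one concentration tested and lower numbers for a weaker effect), compound 1 gives 54%, compound 2 gives 55% and compound 3 gives 90%. Compound 2 is second highest of the three, with a number 1 percentage points higher from compound 1 to compound 2 (within the scatter) and a number 35 percentage points higher from compound 2 to compound 3 (beyond the scatter). Compound 4 `Clc1cccc(NCc2ccc(CNc3ncccn3)cc2)n1` differs from compound 2 by 6-chloropyridin-2-yl in place of phenyl on an amine nitrogen. For the measured compounds named here, the one step that bears on this is the swap of phenyl for a halogen-bearing pyridinyl on the same nitrogen, which gave a number 35 percentage points higher from compound 2 to compound 3 (beyond the scatter); the new group is again a halogen-bearing pyridinyl, though the halogen and its ring position differ, so a rise beyond the scatter is expected, but with less confidence. Compound 4 is therefore estimated at 75%, between 50% and 95%, an expected step of a number 20 percentage points higher from compound 2 to compound 4 (beyond the scatter).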

Compound 4, a percentage reported as inhibition, at one concentration (the size of the read-out at that concentration, not a potency): 100%
The estimate for compound 4 lay 25 percentage points below the measured number; measured number outside the range, above it.
By their numbers in this assay, from the lowest: compounds 1 and 2 (each within the scatter of the next); then compounds 3 and 4 (each within the scatter of the next).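

The gain at this amine nitrogen is not confined to 5-fluoropyridin-2-yl: 6-chloropyridin-2-yl in place of phenyl also brings a large rise (a number 45 percentage points higher from compound 2 to compound 4 (beyond the scatter)). Exchanging one halogen-bearing pyridinyl for the other gives no change that can be told apart from scatter (a number 10 percentage points higher from compound 3 to compound 4 (within the scatter)), so compound 3 and compound 4 cannot be ranked. No measured evidence here explains why either group improves on phenyl.

Going by these compounds, whether plain pyridin-2-yl, without any halogen, or 6-methylpyridin-2-yl would match these two groups remains open.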